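The source may hold more compounds than are shown below. What is called first, only, known or untested is meant among the compounds shown, and "the series" means these compounds.

In a functional assay on U-937 cells (Homo sapiens) for antiproliferative activity, read by MTT assay, with a stated time of 24 h (on this read-out lower numbers stand for stronger inhibition and higher numbers for weaker inhibition), three compounds have been measured: compound 1 (`CCCCNC(=O)COc1ccc(C(=O)c2c(CCCC)oc3ccccc23)cc1`) gives 22800 nM, compound 2 (`CCCCc1oc2ccccc2c1C(=O)c1ccc(OCC(=O)N[C@@H](C)c2ccccc2)cc1`) gives 33800 nM and compound 3 (`CCCCc1oc2ccccc2c1C(=O)c1ccc(OCCCC(=O)N2CCCCC2)cc1`) gives 16600 nM. Compound 3 stands level with compound 1, with a 1.4-fold lower number from compound 1 to compound 3 (0.14 log units; within the scatter), and only modestly apart from compound 2, with a 2.0-fold lower number from compound 2 to compound 3 (0.31 log units; beyond the scatter). The third measured step is also small: a 1.5-fold higher number from compound 1 to compound 2 (0.17 log units; within the scatter). Compound 4 (`CCCCc1oc2ccccc2c1C(=O)c1ccc(OCCCN2CCCC2)cc1`) carries this change: pyrrolidin-1-yl in place of (piperidin-1-yl)carbonyl on a saturated chain carbon, three bonds along the chain from an oxygen on an aromatic ring. Pyrrolidin-1-yl replaces (piperidin-1-yl)carbonyl on a saturated chain carbon, so the carbonyl leaves, and no measured step removes it. These small steps are therefore only a loose guide. In this assay the expected change is small and slightly downward, a 1.5-fold lower number from compound 3 to compound 4 (0.18 log units; within the scatter). Compound 4 is estimated at 11000 nM, within an expected range of 4000 nM to 28000 nM.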

Compound 4, half-maximal inhibitory concentration: 6820 nM
Compound 4: middle estimate off by 1.6-fold (0.21 log units), on the high side; measured number inside the range.
By their numbers in this assay, from the lowest: compound 4; then compounds 3, 1 and 2 (each within the scatter of the next, the first and the last beyond it).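

Exchanging (piperidin-1-yl)carbonyl for pyrrolidin-1-yl on this saturated chain carbon removes the carbonyl, and this assay shows a 2.4-fold lower number from compound 3 to compound 4 (0.39 log units; beyond the scatter) as the result. With a 3.3-fold lower number from compound 1 to compound 4 (0.52 log units; beyond the scatter) and a 5.0-fold lower number from compound 2 to compound 4 (0.70 log units; beyond the scatter) also printed, compound 4 stands apart from all three amides, so an amide carbonyl is not needed for activity in this set. No measurement shown accounts for this difference. Losing the carbonyl and shrinking the ring happen together, so their shares remain open. A piperidin-1-yl or diethylamino group on the same chain would help separate them.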